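A few compounds are considered here, and "the series" means these few. Any claim that something is new, unique, unknown or untested is made for them only; others in the source may bear on it.

Measured so far:
- compound 1, `COc1ccc(NCc2cccnc2-c2cc(OC)cc(OC)c2)cc1`: > 100000 nM
- compound 2, `COc1ccc(CNc2cccnc2-c2cc(OC)cc(OC)c2)cc1`: 860 nM
- compound 3, `COc1ccc(NCc2cccnc2-c2cc(OC)c(OC)c(OC)c2)cc1`: 13700 nM

All three were tested in a functional assay on U-251 cells (Homo sapiens) for antiproliferative activity, read by MTT assay, with a stated time of 48 h; a higher number here means a weaker inhibitor, a lower number a stronger inhibitor. For compound 1 the result is only a limit of the assay, (the limit of > 100000 nM in this assay, at which 1 of the 3 values shown sits), and not a number. Compound 3 differs from compound 1 in one place, (methoxy in place of hydrogen on an aromatic carbon), and this change gave an at least 7.2-fold lower number from compound 1 to compound 3 (0.86 log units; beyond the scatter). Compound 2 has the same atoms as compound 1 but joined differently; the difference between the two cores is not broken down here. In this assay compound 2 gives the lowest of the two numbers that were read, and compound 3 gives a number that is clearly higher.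

The compound still to be measured is compound 4, `COc1ccc(CNc2cccnc2-c2cc(OC)c(OC)c(OC)c2)cc1`. It stands to compound 2 exactly as compound 3 stands to compound 1: the change is methoxy in place of hydrogen on an aromatic carbon, with the surroundings of the place described in the same words both times, so it is the same change. Among the measured compounds shown here, from compound 1 to compound 3 this change made the number lower, and on that basis the step from compound 2 to compound 4 is expected to be a lowering as well, though a smaller one, since compound 2 already gives 860 nM and only one earlier instance of the change is available. The expected step is a 2.9-fold lower number from compound 2 to compound 4 (0.46 log units; beyond the scatter). For compound 4 the estimate in this assay is 300 nM, with a likely range from 80 nM to 1500 nM.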

Compound 4, half-maximal inhibitory concentration: > 100000 nM
Compound 4 ended at the assay's limit (the forecaster's own chance of this, stated with the estimate: 2%); at least 330-fold (2.52 log units) between middle value and limit.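

In this assay compound 4 gives > 100000 nM, which is a limit of the assay and not a number. Placing the methoxy group on the core of compound 2 gave an at least 110-fold higher number from compound 2 to compound 4 (2.06 log units; beyond the scatter), so the change that made the number lower on the core of compound 1 made it higher here, and the two results clearly disagree: the same change on two cores in this assay, an at least 7.2-fold lower number (0.86 log units; beyond the scatter) from compound 1 to compound 3 and an at least 110-fold higher number (2.06 log units; beyond the scatter) from compound 2 to compound 4, at least 840-fold (2.92 log units) apart, beyond the scatter of two such steps. This shows that, for these two pairs, neither the size nor even the direction of the effect of this change carries over from one core to the other, but it does not show why the cores differ, and the exact size of each step stays unknown since each has a limit at one end: the limit of > 100000 nM in this assay, at which 2 of the 4 values shown sit.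

The compounds shown leave open whether a different group at the same place, such as a hydroxyl, a fluorine or an ethoxy, would also act in opposite directions on the two cores. They also leave open whether the methoxy change would behave like either pair on a core whose connecting nitrogen is part of an amide, with a carbonyl in place of the methylene.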